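This account rests on a few compounds, and the source may have more. Where it says the series, first, only, none or still open, it means among the compounds named here.

Measured in an ADME assay on MCF-10A cells (Homo sapiens) for inhibition, with a stated time of 48 h; on this read-out lower numbers stand for stronger inhibition and higher numbers for weaker inhibition:
Compound 1 `O=C(Nc1ccc(Br)cc1)N1CCC[C@H]1c1nc(-c2ccccc2)no1`: > 50000 nM, a limit
Compound 2 `O=C(Nc1ccc(I)cc1)N1CCC[C@H]1c1nc(-c2ccccc2)no1`: > 50000 nM, a limit
Compound 3 `O=C(Nc1ccc(Cl)cc1)N1CCC[C@H]1c1nc(-c2ccccc2Cl)no1`: > 50000 nM, a limit

Compound 3 has no number, only a limit, and the series as a whole shows (the limit of > 50000 nM in this assay, at which 3 of the 3 values shown sit). Compound 4 `N#Cc1cccc(-c2noc([C@@H]3CCCN3C(=O)Nc3ccc(Cl)cc3)n2)c1` differs from it by 3-cyanophenyl in place of 2-chlorophenyl on an aromatic carbon. Going by the values given here, the only measured step is a step that the two limits leave unreadable from compound 1 to compound 2, with iodo in place of bromo, so it gives no size for this change. No step beyond the scatter is expected in this assay because compound 3 shares (the limit of > 50000 nM in this assay, at which 3 of the 3 values shown sit). The expected step is a number no higher from compound 3 to compound 4 (the limit leaves the size open). For compound 4 the estimated value is 50000 nM, with an expected range of 20000 nM to 100000 nM, and a reading at the limit is the likeliest outcome.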

Compound 4, half-maximal inhibitory concentration: > 50000 nM
Compound 4 was reported as a limit; the forecaster's own chance of this, stated with the estimate: 80%; the middle value lies on the limit itself.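

In this assay, compound 3 and compound 4 are both reported only as limits, so the step between them cannot be read. The compounds shown leave open how strongly any of them inhibits, as all share a single reading: the limit of > 50000 nM in this assay, at which 4 of the 4 values shown sit.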